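A few compounds are considered here, and "the series" means these few. Any claim that something is new, unique, unknown or untested is made for them only; others in the source may bear on it.

Measured compounds:
compound 1 `COc1ccc(CN(C(=O)CSc2nc3ccc(OC)cc3s2)c2cc(OC)c(OC)c(OC)c2)cc1` — in a functional assay on ECa-109 cells for antiproliferative activity against ECa-109 cell line (Homo sapiens), read by MTT assay, with a stated time of 48 h (on this read-out lower numbers stand for stronger inhibition and higher numbers for weaker inhibition), compound 1 gives > 80000 nM, which is a limit of the assay and not a number (the limit of > 80000 nM in this assay, at which 1 of the 3 values shown sits).
compound 2 `COc1ccc(CN(C(=O)CSc2nc3ccccc3[nH]2)c2cc(OC)c(OC)c(OC)c2)cc1` — in this assay compound 2 gives 42600 nM.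
compound 3 `COc1ccc(CN(C(=O)CCSc2nc3ccccc3o2)c2cc(OC)c(OC)c(OC)c2)cc1` — in this assay compound 3 gives 12600 nM.

Compound 3 holds the lowest of the two numbers shown; its nearest neighbour is compound 2, with a 3.4-fold lower number from compound 2 to compound 3 (0.53 log units; beyond the scatter). Against compound 1 the step is an at least 6.3-fold lower number from compound 1 to compound 3 (0.80 log units; beyond the scatter). Between compound 1 and compound 2 there is an at least 1.8-fold lower number from compound 1 to compound 2 (0.27 log units; that floor lies within the scatter), which stays within the scatter.

Compound 4 `COc1ccc(CN(C(=O)CSC2=CN=NC2C)c2cc(OC)c(OC)c(OC)c2)cc1` differs from compound 3 at the same place where both measured steps acted: a group of 7 heavy atoms (4 carbon, 2 nitrogen, 1 sulfur; one five-membered non-aromatic ring with 2 hetero atoms) in place of a group of 11 heavy atoms (8 carbon, 1 nitrogen, 1 oxygen, 1 sulfur; one five-membered aromatic ring with 2 hetero atoms, one six-membered aromatic ring of carbon only), on a saturated chain carbon bound to a carbonyl carbon. The two steps bearing on this site, from compound 1 and from compound 2 to compound 3, were modest and both lowered the number, but each exchanged one bicyclic aromatic group for another. The change to compound 4 removes that bicyclic aromatic group altogether and brings in a smaller non-aromatic ring, so those steps give only loose guidance. The expectation is a modest rise in number, with wide uncertainty. Compound 4 is expected to give 30000 nM, in a range from 8000 nM to 80000 nM. The expected step is a 2.4-fold higher number from compound 3 to compound 4 (0.38 log units; beyond the scatter).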

Compound 4, half-maximal inhibitory concentration: > 80000 nM
Compound 4: no number, only a limit (the forecaster's own chance of this, stated with the estimate: 25%); middle value at least 2.6-fold (0.42 log units) from the limit.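

In this assay compound 4 gives > 80000 nM, a limit of the assay and not a number: the limit of > 80000 nM in this assay, at which 2 of the 4 values shown sit.

Among the compounds shown here, on a saturated chain carbon bound to a carbonyl carbon, the earlier compounds only exchanged one bicyclic aromatic group for another, whereas the smaller non-aromatic ring here gives an at least 6.3-fold higher number from compound 3 to compound 4 (0.80 log units; beyond the scatter). The other readable step is an at least 1.8-fold higher number from compound 2 to compound 4 (0.27 log units; that floor lies within the scatter), whose floor lies within the scatter and so sets no firm order; the step between compound 1 and compound 4 cannot be read, since both values are limits.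

Going by these compounds, it remains open whether the result follows from losing the bicyclic aromatic group or from the particular non-aromatic ring that enters. On these data alone, how a phenyl or an imidazole on the sulfur would read also remains open.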